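Urea aryl ring: removing trifluoromethyl from compound 3

This account rests on a few compounds, and the source may have more. Where it says the series, first, only, none or still open, it means among the compounds named here.

Within the data shown here, compound 3 `Cc1ccc(C(CCCCNC(=O)Nc2ccc(Cl)c(C(F)(F)F)c2)c2ccc(C)cc2)cc1` gives 38% in an ADME assay on isolated protein for inhibition of sodium-dependent dopamine transporter (Homo sapiens), tested at 10 uM (on this read-out lower numbers stand for less inhibition and higher numbers for more inhibition at the one concentration tested (going by the name of the read-out)), the second highest of the three numbers so far; compound 1 `O=C(NCCCCC(c1ccc(F)cc1)c1ccc(F)cc1)Nc1ccc(I)cc1` gives 24%, the nearest value, and compound 2 `CC(=O)Nc1cc(NC(=O)NCCCCC(c2ccc(F)cc2)c2ccc(F)cc2)ccc1Cl` gives 76%, the furthest. Among the measured compounds shown here, the one measured step that alters the same aryl ring on the urea nitrogen, a number 52 percentage points higher from compound 1 to compound 2 (beyond the scatter), shows that substitution on this ring can move the read-out a long way, though it swaps in a different group and a different core. Compound 4 `Cc1ccc(C(CCCCNC(=O)Nc2ccc(Cl)cc2)c2ccc(C)cc2)cc1` differs from compound 3 only by hydrogen in place of trifluoromethyl on an aromatic carbon, leaving the 4-chlorophenyl with no other substituent. For the measured compounds named here, no measured pair isolates this change, so the direction is open; the size of the step from compound 1 to compound 2 suggests the ring is sensitive, but a single removal is expected to be smaller. Compound 4 is estimated at 30% in this assay, within 10% to 55%, meaning an expected step of a number 8 percentage points lower from compound 3 to compound 4 (within the scatter), likely not beyond the scatter.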

Compound 4, a percentage reported as inhibition, at one concentration (the size of the read-out at that concentration, not a potency): 59%
The estimate for compound 4 lay 29 percentage points below the measured number; the whole stated range lies below it.
By their numbers in this assay, from the lowest: compound 1; then compound 3; then compound 4; then compound 2.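

In this assay, taking trifluoromethyl off the 4-chloro-3-(trifluoromethyl)phenyl group gives a number 21 percentage points higher from compound 3 to compound 4 (beyond the scatter), so this one change, ortho to the chloro group, moves the read-out beyond the scatter on its own. Unlike the earlier step, which exchanged one whole aryl group for another, this pair isolates a single substituent on the urea aryl ring, and on this core trifluoromethyl goes with the lower number. Nothing available bears on why the removal raises the number.

From the compounds shown here alone, whether the same removal gives a step of similar direction and size on the core of compound 1 remains open. Also open, going by these compounds, is how a nitrile or a primary amine at this place would compare with hydrogen and trifluoromethyl.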